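Aryl Sulfonamide Variation on a Shared Indazolyl Core

The source may report more compounds than this note shows. Statements on the series, on what has been measured and on what is new or still open speak of the compounds shown alone.

Measured compounds:
compound 1 `CN(C(=O)CCc1ccccc1)c1ccc2[nH]c(-c3n[nH]c4ccccc34)cc2n1` gives 7380 nM
compound 2 `COc1ccc(C(=O)N(C)c2ccc3[nH]c(-c4n[nH]c5ccccc45)cc3n2)cc1` gives 12900 nM
compound 3 `CN(c1ccc2[nH]c(-c3n[nH]c4ccccc34)cc2n1)S(=O)(=O)c1ccc(Br)cc1` gives 7150 nM

In a functional assay on KB cells (Homo sapiens) for antiproliferative activity, read by MTT assay, with a stated time of 72 h (on this read-out higher numbers stand for weaker inhibition and lower numbers for stronger inhibition), compound 3 holds the lowest number of the three, though its gaps to compound 1 and compound 2 both lie within the scatter. Compound 4 `COc1ccc(S(=O)(=O)N(C)c2ccc3[nH]c(-c4n[nH]c5ccccc45)cc3n2)c(OC)c1` arises from compound 3 by 2,4-dimethoxyphenyl in place of 4-bromophenyl on a sulfonyl sulfur. Going by the values given here, two measured steps bear on it: a 1.7-fold higher number from compound 1 to compound 2 (0.24 log units; within the scatter), where a methoxy-bearing aryl replaced a phenethyl group, and a 1.8-fold lower number from compound 2 to compound 3 (0.26 log units; within the scatter), which exchanged methoxyaryl carbonyl for bromoaryl sulfonyl. Neither step left the scatter, so no movement beyond it is expected here either. Compound 4 is therefore estimated at 9000 nM, within 3500 nM to 25000 nM, a step of a 1.3-fold higher number from compound 3 to compound 4 (0.10 log units; within the scatter).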

Compound 4, half-maximal inhibitory concentration: 10200 nM
For compound 4 the middle estimate is 1.1-fold (0.05 log units) below the measured one, and the stated range covers the measured number.
By their numbers in this assay, from the lowest: compounds 3, 1, 4 and 2 (each within the scatter of the next).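

In this assay, 2,4-dimethoxyphenyl in place of 4-bromophenyl gives a 1.4-fold higher number from compound 3 to compound 4 (0.15 log units; within the scatter) and so stays within the scatter. The earlier steps shown here varied the group on a carbonyl carbon or exchanged carbonyl for sulfonyl, whereas this one shows that the aryl group on a sulfonyl sulfur can carry methoxy groups instead of bromine with no change beyond the scatter. Nothing available here accounts for this result.

As far as these compounds go, whether an amine or a carboxylic acid on that aryl ring would move the number beyond the scatter remains open. So does the outcome of a longer chain in place of the aryl group on the sulfonyl sulfur.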